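Swapping the Ether Tail and Expected Microsomal Stability

A few compounds are considered here, and "the series" means these few. Any claim that something is new, unique, unknown or untested is made for them only; others in the source may bear on it.

Compound 2 `Cc1nc(C)c([C@H](OC(C)(C)C)C(=O)O)c(N2CCC(C)(C)CC2)c1-c1ccc(OC2COCC2c2ccc(F)cc2)cc1` was tested in an ADME assay on microsomes from liver (Rattus norvegicus) for metabolic stability, read by LC-MS, tested at 0.5 uM; on this read-out lower numbers stand for a shorter-lived compound and higher numbers for a longer-lived compound. In this assay compound 2 gives > 2 h, which is a limit of the assay rather than a number. Compound 1 `COc1cccc(CCOc2ccc(-c3c(C)nc(C)c([C@H](OC(C)(C)C)C(=O)O)c3N3CCC(C)(C)CC3)cc2)c1` also stands at a limit in this assay, giving > 2 h. The step that the two limits leave unreadable from compound 1 to compound 2 is therefore not readable, as the limit of > 2 h in this assay, at which 2 of the 2 values shown sit, shows. Compound 3 `Cc1nc(C)c([C@H](OC(C)(C)C)C(=O)O)c(N2CCC(C)(C)CC2)c1-c1ccc(OCCc2ccccn2)cc1` differs from compound 2 by 2-(pyridin-2-yl)ethyl in place of 4-(4-fluorophenyl)oxolan-3-yl on an oxygen on an aromatic ring. Among the compounds with values here, no measured step in this assay bears on this change, so the expectation rests only on where the measured compounds sit. Compound 3 is therefore expected to give 2 h, between 0.7 h and 4 h, an expected step of a number no higher from compound 2 to compound 3 (the limit leaves the size open) that is not beyond the scatter.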

Compound 3, half-life: 1.02 h
The estimate for compound 3 lay 2.0-fold (0.29 log units) above the measured number; measured number inside the range.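

In this assay compound 3 alone gives a number rather than a limit, so a tail on this oxygen can bring the half-life into the readable range. The change reads as an at least 1.9-fold lower number from compound 2 to compound 3 (0.29 log units; that floor lies within the scatter), and swapping 3-methoxyphenyl for pyridin-2-yl on the same chain reads as an at least 1.9-fold lower number from compound 1 to compound 3 (0.29 log units; that floor lies within the scatter). Both floors lie within the scatter, and the full size of each step stays open because the other two compounds sit at a limit: the limit of > 2 h in this assay, at which 2 of the 3 values shown sit.

Still open, on these data alone, is whether a 2-(pyridin-3-yl)ethyl, a plain 2-phenylethyl or a longer chain on this oxygen would give a number or a limit.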